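A few compounds are considered here, and "the series" means these few. Any claim that something is new, unique, unknown or untested is made for them only; others in the source may bear on it.

Compound 1 `O=C1C(Nc2ccc(I)cc2)=CC(=O)c2c1nc1n2[C@H]2OC[C@@H](O)[C@H]2OC1`: 2530 nM
Compound 2 `O=C1C(Nc2ccccc2)=CC(=O)c2c1nc1n2[C@H]2OC[C@@H](O)[C@H]2OC1`: 3560 nM
Compound 3 `O=C1C(N2CCCC2)=CC(=O)c2c1nc1n2[C@H]2OC[C@@H](O)[C@H]2OC1`: > 16000 nM

These values come from a functional assay on ECa-109 cells for inhibition, with ECa-109 cell line (Homo sapiens) as the target, read by sulforhodamine B assay; a lower number here means a stronger inhibitor, a higher number a weaker inhibitor. Compound 3 gives > 16000 nM there, and this is a limit of the assay and not a number. Its steps from the other two compounds both lie beyond the scatter, which places compound 3 at the weak end of this small set: an at least 6.3-fold higher number from compound 1 to compound 3 (0.80 log units; beyond the scatter), and an at least 4.4-fold higher number from compound 2 to compound 3 (0.65 log units; beyond the scatter). The iodo group on the aromatic ring matters far less, since a 1.4-fold higher number from compound 1 to compound 2 (0.15 log units; within the scatter).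

Compound 4 `O=C1C(N2CCC2)=CC(=O)c2c1nc1n2[C@H]2OC[C@@H](O)[C@H]2OC1` keeps the shared core and carries azetidin-1-yl in place of pyrrolidin-1-yl on a double-bonded ring carbon. Among the measured compounds shown here, no measured step swaps one such ring for another. The larger steps involve the loss of the anilino or (4-iodophenyl)amino group, and compound 4 lacks these groups just as compound 3 does. No step beyond the scatter is therefore expected in this assay, and a report as a limit again is quite possible. The estimated change is a step that the limit leaves unreadable from compound 3 to compound 4. For compound 4 the expected value is 18000 nM, with an estimated range of 7000 nM to 45000 nM.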

Compound 4, half-maximal inhibitory concentration: > 16000 nM
Compound 4: a limit, no number; the forecaster's own chance of this, stated with the estimate: 60%; the middle value lies beyond the limit too.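

In this assay, azetidin-1-yl in place of anilino gives an at least 4.4-fold higher number from compound 2 to compound 4 (0.65 log units; beyond the scatter), and azetidin-1-yl in place of (4-iodophenyl)amino gives an at least 6.3-fold higher number from compound 1 to compound 4 (0.80 log units; beyond the scatter). Pyrrolidin-1-yl is therefore no longer the only non-aromatic ring on this double-bonded ring carbon that falls well short of the two aromatic amino groups. The step between compound 3 and compound 4 cannot be read, and any effect of the smaller ring stays hidden, because both compounds stop at the same assay limit: the limit of > 16000 nM in this assay, at which 2 of the 4 values shown sit.

From the compounds shown here alone, how far apart compound 3 and compound 4 truly lie remains open. Going by these compounds, it is also open whether a benzylamino group or an open-chain amine such as dimethylamino on this carbon would give a measurable value.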